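From pyridin-4-yl to (trifluoromethyl)carbonyl on the shared core

This account rests on a few compounds, and the source may have more. Where it says the series, first, only, none or still open, it means among the compounds named here.

Measured so far:
- compound 1 `CC(C)c1cc(-c2ccccn2)c(-c2ccc(F)cc2)n1CC[C@@H]1C[C@@H](O)CC(=O)O1` gives 46 nM in an assay for inhibition of 3-hydroxy-3-methylglutaryl-coenzyme A reductase (Rattus norvegicus); on this read-out lower numbers stand for stronger inhibition and higher numbers for weaker inhibition
- compound 2 `CC(C)c1cc(-c2ccncc2)c(-c2ccc(F)cc2)n1CC[C@@H]1C[C@@H](O)CC(=O)O1` gives 310 nM in this assay

Among the measured compounds shown here, compound 2 has the higher of the two numbers; the single measured step, a 6.7-fold higher number from compound 1 to compound 2 (0.83 log units; beyond the scatter), lies beyond the scatter. Compound 3 `CC(C)c1cc(C(=O)C(F)(F)F)c(-c2ccc(F)cc2)n1CC[C@@H]1C[C@@H](O)CC(=O)O1` differs from compound 2 by (trifluoromethyl)carbonyl in place of pyridin-4-yl on an aromatic carbon. No measured step covers this exchange: the one step shown swaps one pyridinyl for another, and it only indicates that this position can move the number noticeably. The direction remains uncertain; compound 3 is expected to show a moderate step downward, a 3.1-fold lower number from compound 2 to compound 3 (0.49 log units; beyond the scatter), with a wide range. Compound 3 is thus estimated at 100 nM, between 25 nM and 400 nM.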

Compound 3, half-maximal inhibitory concentration: 800 nM
For compound 3 the middle estimate is 8.0-fold (0.90 log units) below the measured one; measured number outside the range, above it.
By their numbers in this assay, from the lowest: compound 1; then compound 2; then compound 3.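

In this assay, putting (trifluoromethyl)carbonyl in place of pyridin-4-yl gives a 2.6-fold higher number from compound 2 to compound 3 (0.41 log units; beyond the scatter), and putting it in place of pyridin-2-yl gives a 17-fold higher number from compound 1 to compound 3 (1.24 log units; beyond the scatter). Among the compounds shown here, compound 3, the only one here with no ring at this position, is thus the weakest of the three, so a pyridinyl ring is not needed for measurable inhibition, though both pyridinyl compounds do better. No available evidence explains this order. For the compounds shown here, with only one ringless group, these compounds cannot show whether losing the ring or the entering group itself matters more. A plain phenyl ring or a primary amide at this position could help separate the two.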